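Swapping a Hexyloxy Chain for Iodine: What to Expect

This account rests on a few compounds, and the source may have more. Where it says the series, first, only, none or still open, it means among the compounds named here.

Three compounds have been measured in an assay for inhibition of Dihydrofolate reductase (Gallus gallus); a higher number here means a weaker inhibitor, a lower number a stronger inhibitor:
compound 1 `Cc1ccccc1Cc1cnc(N)nc1N` gives 29500 nM;
compound 2 `Nc1ncc(Cc2ccccc2Br)c(N)n1` gives 12300 nM;
compound 3 `CCCCCCOc1ccccc1Cc1cnc(N)nc1N` gives 7940 nM.

Compound 3 carries the lowest of the three numbers, but its gap to compound 2 lies within the scatter, so the two cannot be ranked; only compound 1 is clearly set apart, as a 3.7-fold lower number from compound 1 to compound 3 (0.57 log units; beyond the scatter) shows.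

Compound 4 `Nc1ncc(Cc2ccccc2I)c(N)n1` is not yet measured. It differs from compound 3 by iodo in place of hexyloxy on an aromatic carbon. The step that bears on this most closely is a 1.5-fold lower number from compound 2 to compound 3 (0.19 log units; within the scatter), which compares the hexyloxy group with another halogen and found no difference beyond the scatter. The step of a 2.4-fold lower number from compound 1 to compound 2 (0.38 log units; beyond the scatter) shows that a halogen in this place gave a modestly lower number than methyl. Since one halogen matched hexyloxy within the scatter, iodine is expected to do much the same, and no step beyond the scatter is expected: a 1.3-fold higher number from compound 3 to compound 4 (0.10 log units; within the scatter). Compound 4 is therefore estimated at 10000 nM, with a range from 4000 nM to 25000 nM.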

Compound 4, inhibition constant: 8710 nM
Estimate against measurement, compound 4: 1.1-fold (0.06 log units) above; low and high end bracket the measured number.
By their numbers in this assay, from the lowest: compounds 3, 4 and 2 (each within the scatter of the next); then compound 1.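

At this position, a lone iodine atom and a hexyloxy chain of 7 heavy atoms cannot be told apart (a 1.1-fold higher number from compound 3 to compound 4 (0.04 log units; within the scatter)), so the size of the change in atom count is not matched by any readable change in the number. Iodo also cannot be separated from bromo (a 1.4-fold lower number from compound 2 to compound 4 (0.15 log units; within the scatter)), yet it stands clear of methyl (a 3.4-fold lower number from compound 1 to compound 4 (0.53 log units; beyond the scatter)), leaving compound 1 as the only one of the four set apart. Nothing available accounts for this match between such different groups.

Only methyl, two halogens and hexyloxy are shown here, so it stays open whether an amine, a carboxylic acid or a shorter chain such as methoxy would fall in the same range. Also open, going by these compounds, is whether any group in this place can bring the number far below that of compound 3 (7940 nM).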